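Thiazolyl carbamoyl in place of hydroxymethyl: expected step

This account rests on a few compounds, and the source may have more. Where it says the series, first, only, none or still open, it means among the compounds named here.

Values in a functional assay on blood (Homo sapiens), with a stated time of 60 min, in the presence of a further agent that is not named here; a lower number here means that less compound is needed, a higher number that more compound is needed for the effect:
- compound 1 `COC(=O)C1(S(=O)(=O)c2ccc(Oc3ccc(OC(F)(F)F)cc3)cc2)CCC2(CCNCC2)C1`: > 15000 nM, a limit
- compound 2 `O=C(Oc1ccccc1)C1(S(=O)(=O)c2ccc(Oc3ccc(OC(F)(F)F)cc3)cc2)CCC2(CCNCC2)C1`: 900 nM
- compound 3 `O=S(=O)(c1ccc(Oc2ccc(OC(F)(F)F)cc2)cc1)C1(CO)CCC2(CCNCC2)C1`: > 15000 nM, a limit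

Compound 3 stands only at a limit, > 15000 nM.

Compound 4 `O=C(Nc1nccs1)C1(S(=O)(=O)c2ccc(Oc3ccc(OC(F)(F)F)cc3)cc2)CCC2(CCNCC2)C1` carries (1,3-thiazol-2-yl)carbamoyl in place of hydroxymethyl on a saturated ring carbon.

The nearest evidence is the large at least 16-fold higher number from compound 2 to compound 3 (1.22 log units; beyond the scatter), with the large at least 16-fold lower number from compound 1 to compound 2 (1.22 log units; beyond the scatter) in support. The entering group is closest to the phenoxycarbonyl of compound 2, which gives 900 nM. Going by the values given here, no carbamoyl compound has been measured, so the comparison is loose.

A large step toward a lower number in this assay is expected, estimated as an at least 10-fold lower number from compound 3 to compound 4 (1.00 log units; beyond the scatter). For compound 4 the estimate is 1500 nM, with an expected range of 150 nM to 12000 nM.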

Compound 4, half-maximal effective concentration: > 15000 nM
Compound 4: only a limit was reported (the forecaster's own chance of this, stated with the estimate: 25%); middle value at least 10-fold (1.00 log units) from the limit.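

In this assay, (1,3-thiazol-2-yl)amino in place of phenoxy on the carbonyl carbon gives an at least 16-fold higher number from compound 2 to compound 4 (1.22 log units; beyond the scatter), so a ring-bearing group on this carbonyl does not by itself keep the activity of compound 2. Compound 4 gives > 15000 nM, which is a limit. The steps from compound 1 and compound 3 to compound 4 cannot be read, because all three compounds stand at the same limit: the limit of > 15000 nM in this assay, at which 3 of the 4 values shown sit.

On these data alone, whether a phenylcarbamoyl or a carboxylic acid on this ring carbon would give a measurable value remains open. As far as these compounds go, how far compound 4 lies past its limit also remains open.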